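Acrylamide series: aryl swap on the alkene carbon

This account rests on a few compounds, and the source may have more. Where it says the series, first, only, none or still open, it means among the compounds named here.

Compound 1 `N#C/C(=C\c1ccc[nH]1)C(=O)NCc1ccc(Cl)c(Cl)c1` is the starting point. In a functional assay on SMA cells (Homo sapiens) for inhibition, read by MTT assay, with a stated time of 72 h (on this read-out higher numbers stand for weaker inhibition of growth and lower numbers for stronger inhibition of growth), compound 1 reaches only the limit of the measurement, > 50000 nM, so no number is known for it; it sits at the limit of > 50000 nM in this assay, at which 1 of the 2 values shown sits. Within the data shown here, compound 2 `COc1ccc(CNC(=O)/C(C#N)=C/c2ccoc2)cc1`, which carries a different amide substituent and a furanyl ring on the alkene, gives 7000 nM in this assay, and is the only compound here with a measured number. Compound 3 `COc1ccc(/C=C(\C#N)C(=O)NCc2ccc(Cl)c(Cl)c2)cc1` differs from compound 1 by 4-methoxyphenyl in place of 1H-pyrrol-2-yl on a double-bonded chain carbon bound to a double-bonded chain carbon. Among the measured compounds shown here, no measured step covers this change, so the direction is taken from compound 2, whose value of 7000 nM shows that an acrylamide of this kind can inhibit growth at all. A gain beyond the scatter is expected, though its size is uncertain because compound 1 stands at the limit of > 50000 nM in this assay, at which 1 of the 2 values shown sits. Compound 3 is estimated at 15000 nM in this assay, between 4000 nM and 50000 nM. The expected step from an at least 3.3-fold lower number from compound 1 to compound 3 (0.52 log units; beyond the scatter) therefore points toward stronger inhibition.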

Compound 3, concentration for 50% growth inhibition: > 100000 nM
Compound 3 gave a limit, no number; the forecaster's own chance of this, stated with the estimate: 30%; middle value at least 6.6-fold (0.82 log units) from the limit.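

In this assay compound 3 gives > 100000 nM, a limit and not a number. Among these compounds, compound 1 also stands at a limit, and no step between compound 1 and compound 3 can be read. The compounds shown leave open whether 4-methoxyphenyl in place of 1H-pyrrol-2-yl changes growth inhibition at all.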